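The compounds below may be only part of what the source reports. "The series", "measured", "known", "first", "only" and "open" are said of these compounds alone.

The measured compounds:
Compound 1, `COC(=O)c1cc(-c2cccc(NC(=O)c3ccc(/C=C/C(=O)c4cc(F)ccc4F)cc3)c2)on1`, gives > 40 ug/mL.
Compound 2, `COC(=O)c1cc(-c2cccc(NC(=O)c3ccc(/C=C/C(=O)c4ccc(C)c([N+](=O)[O-])c4)cc3)c2)on1`, gives > 80 ug/mL.
Compound 3, `COC(=O)c1cc(-c2cccc(NC(=O)c3ccc(/C=C/C(=O)c4ccc(OC)cc4OC)cc3)c2)on1`, gives > 50 ug/mL.

These three values come from an ADME assay on Vero cells (Chlorocebus sabaeus) for cytotoxicity, read by MTT assay, with a stated time of 72 h; on this read-out lower numbers stand for higher toxicity in this test and higher numbers for lower toxicity in this test. None of them is a true number: each is a limit of the assay, meaning the cells tolerated the highest concentration tested. Compound 3 sits at the limit of > 50 ug/mL in this assay, at which 1 of the 3 values shown sits. Compound 1 sits at the limit of > 40 ug/mL in this assay, at which 1 of the 3 values shown sits. Compound 2 sits at the limit of > 80 ug/mL in this assay, at which 1 of the 3 values shown sits. With every value a limit, the steps a step that the two limits leave unreadable from compound 1 to compound 2, a step that the two limits leave unreadable from compound 1 to compound 3 and a step that the two limits leave unreadable from compound 2 to compound 3 have no readable size or direction, so the swap of one aryl group for another on the carbonyl carbon has left no visible mark on toxicity here.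

Compound 4, `COC(=O)c1cc(-c2cccc(NC(=O)c3ccc(/C=C/C(=O)c4cccc([N+](=O)[O-])c4)cc3)c2)on1`, is not yet measured. It differs from compound 3 by 3-nitrophenyl in place of 2,4-dimethoxyphenyl on a carbonyl carbon; the 2,4-dimethoxyphenyl leaves and a 3-nitrophenyl enters on a carbonyl carbon whose other neighbour is a double-bonded chain carbon. The steps from compound 1 and compound 2 to compound 3 are the ones that bear on this change, and both are unreadable, so no step beyond the scatter is expected in this assay. The step is estimated as a step that the limit leaves unreadable from compound 3 to compound 4. Compound 4 is expected to give about 60 ug/mL, between 30 ug/mL and 100 ug/mL, most likely again reported as a limit.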

Compound 4, half-maximal cytotoxic concentration: > 40 ug/mL
Compound 4: a limit, no number (the forecaster's own chance of this, stated with the estimate: 80%); the middle value lies beyond the limit too.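

In this assay compound 4 gives > 40 ug/mL, which is a limit and not a number. Among these compounds, compound 1, compound 2 and compound 3 also carry only limits, so no step from any of them to compound 4 can be read. On these data alone, whether swapping the group on the carbonyl carbon changes toxicity at all stays open, as does the true toxicity of all four compounds.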